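Where a Hydroxyl Joins Two Bromines on an Inactive Compound

The source may hold more compounds than are shown below. What is called first, only, known or untested is meant among the compounds shown, and "the series" means these compounds.

The compounds share one core and differ mainly in the aryl group on a carbon with a double bond to nitrogen. Compound 1 `O=C(N/N=C/c1cccc(Br)c1)Nc1cc2c(Nc3ccc(F)c(Cl)c3)ncnc2cc1O[C@H]1CCOC1` in a functional assay on HepG2 cells (Homo sapiens) for cytotoxicity, read by MTT assay, with a stated time of 72 h (on this read-out lower numbers stand for stronger inhibition and higher numbers for weaker inhibition), gives 32300 nM. Among the compounds with values here, compound 2 `CCN(CC)c1ccc(/C=N/NC(=O)Nc2cc3c(Nc4ccc(F)c(Cl)c4)ncnc3cc2O[C@H]2CCOC2)c(O)c1` in this assay gives 15700 nM, and the single measured step, a 2.1-fold lower number from compound 1 to compound 2 (0.31 log units; beyond the scatter), is modest. Compound 3 `COc1cc2ncnc(Nc3ccc(F)c(Cl)c3)c2cc1NC(=O)N/N=C/c1cccc(Br)c1` in this assay is reported as "not active" (no number reported), with no number given, so it cannot be placed on the scale of compounds 1 and 2 at all. Compound 4 `COc1cc2ncnc(Nc3ccc(F)c(Cl)c3)c2cc1NC(=O)N/N=C/c1cc(Br)c(O)c(Br)c1` differs from compound 3 by 3,5-dibromo-4-hydroxyphenyl in place of 3-bromophenyl on a carbon with a double bond to nitrogen. Within the data shown here, no measured step covers this change; the only step in hand, a 2.1-fold lower number from compound 1 to compound 2 (0.31 log units; beyond the scatter), concerns a different aryl replacement and offers at most a modest hint that a hydroxyl-bearing aryl group may lower the number somewhat. Starting from an inactive compound, compound 4 is expected to remain weak in this assay, with a real chance that only a limit is reported. Compound 4 is estimated at 60000 nM, within a range of 20000 nM to 200000 nM.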

Compound 4, half-maximal inhibitory concentration: 36800 nM
For compound 4 the middle estimate is 1.6-fold (0.21 log units) above the measured one, within the range that was stated.
By their numbers in this assay, from the lowest: compound 2; then compounds 1 and 4 (each within the scatter of the next).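

No new step can be read from compound 3 to compound 4: compound 3 is reported only as "not active", without a number. The compounds shown leave open how far 3,5-dibromo-4-hydroxyphenyl in place of 3-bromophenyl shifts the number, and nothing at hand explains the result.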